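Methyl opposite the ring nitrogen: a pyrrolidine thiosemicarbazone

A few compounds are considered here, and "the series" means these few. Any claim that something is new, unique, unknown or untested is made for them only; others in the source may bear on it.

Measured so far:
compound 1 `N/C(=N\NC(=S)N1CCCC1)c1ccc(F)cn1` gives 72.2%
compound 2 `Cc1cccc(/C(N)=N/NC(=S)N2CCCC2)n1` gives 47.2%
compound 3 `N/C(=N\NC(=S)N1CCCC1)c1ccccn1` gives 70.9%

In a functional assay on A-431 cells (Homo sapiens) for cytotoxicity, read by MTT assay, with a stated time of 72 h, tested at 3 uM (a lower number here means less inhibition of growth, a higher number more inhibition of growth at the concentration tested), compound 3 stands second highest of the three; compound 1 is within the scatter of it, and compound 2 lies well below. Compound 4 `Cc1ccnc(/C(N)=N/NC(=S)N2CCCC2)c1` differs from compound 3 by methyl in place of hydrogen on an aromatic carbon. Two measured steps speak to this change. The step of a number 1.3 percentage points lower from compound 1 to compound 3 (within the scatter) shows that a small substituent on this ring can leave this assay unchanged. The step of a number 23.7 percentage points higher from compound 2 to compound 3 (beyond the scatter) shows that removing a methyl from the ring raised the number, though the methyl of compound 2 does not sit where the methyl of compound 4 enters. On that evidence a methyl is more likely to cost than to gain, but the size is uncertain. Compound 4 is therefore expected to fall modestly, by about a number 10.9 percentage points lower from compound 3 to compound 4 (beyond the scatter), giving an estimated 60% with a range of 38% to 78%.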

Compound 4, percent growth inhibition at one concentration: 63%
For compound 4 the middle estimate is 3 percentage points below the measured one; the measured number falls inside the stated range.
By their numbers in this assay, from the lowest: compound 2; then compounds 4, 3 and 1 (each within the scatter of the next).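

In this assay methyl in place of hydrogen opposite the ring nitrogen gave a number 7.9 percentage points lower from compound 3 to compound 4 (within the scatter) and so left the number in place at this position. Compound 2, with its methyl elsewhere on the ring, gives 47.2% while compound 4 gives 63% in the same test, so the low number of compound 2 is not shared by every methyl on this ring. Nothing measured here accounts for this result.

From the compounds shown here alone, whether an ethyl group, a methoxy group or an amine opposite the ring nitrogen would also leave the number in place remains open. So does whether a fluoro group at this position would match the methyl of compound 4, and whether a larger chain there would begin to lower the number.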